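The source may hold more compounds than are shown below. What is called first, only, known or untested is meant among the compounds shown, and "the series" means these compounds.

Measured in a functional assay on SK-BR-3 cells (Homo sapiens) for antiproliferative activity, read by MTT assay, with a stated time of 72 h; a higher number here means a weaker inhibitor, a lower number a stronger inhibitor:
- compound 1, `CCN1CCN(c2cc(C)c3cc(NC(=O)c4cccc(Cl)c4)ccc3n2)CC1`, gives 17800 nM
- compound 2, `CCN1CCN(c2cc(C)c3cc(NC(=O)c4ccc(Cl)cc4)ccc3n2)CC1`, gives 3020 nM
- compound 3, `CCN1CCN(c2cc(C)c3cc(NC(=O)c4cccc(Br)c4)ccc3n2)CC1`, gives 13300 nM

Among these three numbers compound 3 stands second highest in this assay. Its nearest neighbour is compound 1, a step of a 1.3-fold lower number from compound 1 to compound 3 (0.13 log units; within the scatter), which lies within the scatter, so the two cannot be told apart. The furthest is compound 2: a 4.4-fold higher number from compound 2 to compound 3 (0.64 log units; beyond the scatter), a modest step beyond the scatter, in line with a 5.9-fold lower number from compound 1 to compound 2 (0.77 log units; beyond the scatter).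

The next compound, compound 4, `CCN1CCN(c2cc(C)c3cc(NC(=O)c4ccc[nH]4)ccc3n2)CC1`, changes the same part of the molecule: 1H-pyrrol-2-yl in place of 3-bromophenyl on a carbonyl carbon. Both measured steps move a halogen around a six-membered carbon ring or swap one halogen for another; none replaces that ring by a five-membered ring carrying a hydrogen-bond donor. So no measured step bears directly on this change, and the safest expectation in this assay is a number near that of compound 3, with a wide range on either side. The step from compound 3 is expected to be a 1.1-fold higher number from compound 3 to compound 4 (0.05 log units; within the scatter), that is, not clearly beyond the scatter. Compound 4 is therefore estimated at 15000 nM, within a range from 5000 nM to 50000 nM.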

Compound 4, half-maximal inhibitory concentration: 13200 nM
Estimate against measurement, compound 4: 1.1-fold (0.06 log units) above, within the range that was stated.
By their numbers in this assay, from the lowest: compound 2; then compounds 4, 3 and 1 (each within the scatter of the next).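

In this assay the carbonyl carbon accepts 1H-pyrrol-2-yl, a five-membered ring with a hydrogen-bond donor and no halogen, without any change that can be read against 3-bromophenyl: the result is a 1.0-fold lower number from compound 3 to compound 4 (0.00 log units; within the scatter) and so gives no sign that this six-membered ring or its bromine matters here. The comparison with 3-chlorophenyl reads the same way, with a 1.3-fold lower number from compound 1 to compound 4 (0.13 log units; within the scatter), so compounds 1, 3 and 4 cannot be told apart despite the different rings on the carbonyl carbon. Only 4-chlorophenyl stands clearly apart, as a 4.4-fold higher number from compound 2 to compound 4 (0.64 log units; beyond the scatter) shows, which leaves compound 2 the strongest of the four and shows that 1H-pyrrol-2-yl does not match it.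

Nothing measured here gives a reason for these numbers. From the compounds shown here alone, it remains open whether the advantage of compound 2 carries over to 4-bromophenyl or 4-methoxyphenyl on the same carbonyl carbon, and whether 1H-pyrrol-2-yl keeps its number once its ring nitrogen carries a methyl group.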